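Nitro addition on the phenyl ring: cytotoxicity notes

The source may report more compounds than this note shows. Statements on the series, on what has been measured and on what is new or still open speak of the compounds shown alone.

Compound 1 `COc1ccc(-c2nc3cc(Cl)c(Cl)cc3[nH]2)cc1` and compound 2 `O=[N+]([O-])c1ccc(-c2nc3cc(C(F)(F)F)ccc3[nH]2)cc1` share a core; how the two cores differ is not broken down here. In an ADME assay on BHK cells (Mesocricetus auratus) for cytotoxicity, read by MTT assay, with a stated time of 96 h (on this read-out higher numbers stand for lower toxicity in this test and lower numbers for higher toxicity in this test), compound 1 gives 18000 nM and compound 2 gives 18000 nM, values within the scatter of each other. Compound 3 `O=[N+]([O-])c1ccc(-c2nc3cc(C(F)(F)F)ccc3[nH]2)c([N+](=O)[O-])c1` carries the change (nitro in place of hydrogen on an aromatic carbon), and in this assay compound 3 gives 8000 nM, with a 2.3-fold lower number from compound 2 to compound 3 (0.35 log units; beyond the scatter). Compound 4 `COc1ccc(-c2nc3cc(Cl)c(Cl)cc3[nH]2)c([N+](=O)[O-])c1` awaits measurement and carries the same kind of change, (nitro in place of hydrogen on an aromatic carbon); the place differs in being meta to a methoxy group rather than meta to a nitro group. For the measured compounds named here, the step is expected at a 2.3-fold lower number from compound 1 to compound 4 (0.35 log units; beyond the scatter), resting only on the single measured pair a 2.3-fold lower number from compound 2 to compound 3 (0.35 log units; beyond the scatter). For compound 4 the estimate in this assay is 8000 nM, expected between 4000 nM and 16000 nM.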

Compound 4, half-maximal cytotoxic concentration: 80000 nM
Beside the measured number, compound 4's estimate is 10-fold (1.00 log units) below it, outside the stated range (above it).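

On the core of compound 1, nitro in place of hydrogen on an aromatic carbon gives in this assay a 4.4-fold higher number from compound 1 to compound 4 (0.65 log units; beyond the scatter). The change therefore does not carry over from one core to the other in this series, either in direction or in size: the same change on two cores in this assay, a 2.3-fold lower number (0.35 log units; beyond the scatter) from compound 2 to compound 3 and a 4.4-fold higher number (0.65 log units; beyond the scatter) from compound 1 to compound 4, 10-fold (1.00 log units) apart, beyond the scatter of two such steps. For the compounds shown here, with one pair per core, this shows only that a step measured on one core cannot be assumed on the other; it gives no rule for either core and no cause for the gap.

Going by these compounds, it remains open whether the gap follows the core or the methoxy group that compound 4 carries where compound 3 has a second nitro group. Also open, on these data alone, is how an amine or a carboxylic acid in place of the added nitro group would behave on either core.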